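A few compounds are considered here, and "the series" means these few. Any claim that something is new, unique, unknown or untested is made for them only; others in the source may bear on it.

Working notes on the series. All three measured compounds share the core of compound 1 `COc1ccc(-c2cc(=O)c3c(OC)cc(OC)cc3n2C)cc1`, which in an ADME assay on BJ cells (Homo sapiens) for antiproliferative activity, with a stated time of 72 h (a lower number here means that less compound is needed, a higher number that more compound is needed for the effect), gives 68000 nM. Compound 2 `COc1ccc(-c2cc(=O)c3c(OC)cc(OC)cc3n2S(=O)(=O)c2cccc([N+](=O)[O-])c2)cc1` carries a 3-nitrophenyl on the sulfonyl sulfur. In this assay compound 2 reaches only a limit, > 39600 nM. Compound 3 `COc1ccc(-c2cc(=O)c3c(OC)cc(OC)cc3n2S(=O)(=O)c2c(F)c(F)c(F)c(F)c2F)cc1` carries a 2,3,4,5,6-pentafluorophenyl on the sulfonyl sulfur. In this assay compound 3 likewise stops at a limit, > 34400 nM. The step that the two limits leave unreadable from compound 2 to compound 3 cannot be sized because both of its ends are limits (the limit of > 34400 nM in this assay, at which 1 of the 3 values shown sits, and (the limit of > 39600 nM in this assay, at which 1 of the 3 values shown sits)). Compound 3 therefore stands at a limit, one of two limits among the three values shown, and only compound 1 gives an actual number.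

Compound 4 `COc1ccc(-c2cc(=O)c3c(OC)cc(OC)cc3n2S(=O)(=O)Cc2ccccc2)cc1` is the next variation at the sulfonyl sulfur: benzyl in place of 2,3,4,5,6-pentafluorophenyl on a sulfonyl sulfur. Within the data shown here, the only measured step touching this position, a step that the two limits leave unreadable from compound 2 to compound 3, carries no readable size, so no measured step gives a magnitude for this change; what is known is that every compound so far sits weakly in this assay. On that basis the step that the limit leaves unreadable from compound 3 to compound 4 is expected to stay within the scatter. Compound 4 is estimated at about 50000 nM in this assay, in a range from 15000 nM to 150000 nM, with a fair chance that the assay again returns only a limit.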

Compound 4, half-maximal effective concentration: > 34400 nM
Compound 4: only a limit was reported; the forecaster's own chance of this, stated with the estimate: 55%; the middle value is on the limit's open side.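

In this assay compound 4 gives only a limit, > 34400 nM. None of the steps joining compound 4 to compound 1, compound 2 and compound 3 can be read. The compounds shown leave open whether any group on the sulfonyl sulfur gives an actual number in this assay, and how such a number would compare with compound 1.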